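Swapping an Amide for a Sulfonamide on a Shared Core

This account rests on a few compounds, and the source may have more. Where it says the series, first, only, none or still open, it means among the compounds named here.

Compound 1, `CN(C(=O)C(C)(C)C)c1ccc2[nH]c(-c3n[nH]c4ccccc34)cc2n1`, gives 8390 nM in a functional assay on KB cells (Homo sapiens) for antiproliferative activity, read by MTT assay, with a stated time of 72 h; on this read-out lower numbers stand for stronger inhibition and higher numbers for weaker inhibition.
Compound 2, `CN(C(=O)c1ccccc1)c1ccc2[nH]c(-c3n[nH]c4ccccc34)cc2n1`, gives 8580 nM in this assay.
Compound 3, `COc1ccc(C(=O)N(C)c2ccc3[nH]c(-c4n[nH]c5ccccc45)cc3n2)cc1`, gives 12900 nM in this assay.

Compound 1 sits at the low end of the three numbers, but a 1.0-fold higher number from compound 1 to compound 2 (0.01 log units; within the scatter) and a 1.5-fold higher number from compound 1 to compound 3 (0.19 log units; within the scatter) both lie within the scatter, so the three compounds cannot be told apart on these data. The step between the other two, a 1.5-fold higher number from compound 2 to compound 3 (0.18 log units; within the scatter), is also within the scatter.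

Compound 4, `CN(c1ccc2[nH]c(-c3n[nH]c4ccccc34)cc2n1)S(=O)(=O)c1ccc(Cl)cc1`, is the next compound to be tested. It differs from compound 1 in one place: (4-chlorophenyl)sulfonyl in place of (tert-butyl)carbonyl on a nitrogen on an aromatic ring. The measured steps all change the group on the carbonyl carbon while keeping the carbonyl itself; none exchanges the carbonyl for a sulfonyl group, and none adds a chlorine to a ring. They bear on this step only loosely, showing that varying the group on this nitrogen has so far moved the numbers very little. On that basis no step beyond the scatter is expected in this assay, in either direction, though the broader change leaves more room for surprise.

Compound 4 is therefore expected to give about 9000 nM, with a range from 3500 nM to 25000 nM. This estimate corresponds to an expected step of a 1.1-fold higher number from compound 1 to compound 4 (0.03 log units; within the scatter).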

Compound 4, half-maximal inhibitory concentration: 8350 nM
For compound 4 the middle estimate is 1.1-fold (0.03 log units) above the measured one; the measured number falls inside the stated range.
By their numbers in this assay, from the lowest: compounds 4, 1, 2 and 3 (each within the scatter of the next).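

The sulfonyl group with its 4-chlorophenyl ring can stand on this nitrogen in place of each carbonyl group shown without leaving the scatter in this assay (a 1.0-fold lower number from compound 1 to compound 4 (0.00 log units; within the scatter); a 1.0-fold lower number from compound 2 to compound 4 (0.01 log units; within the scatter); a 1.5-fold lower number from compound 3 to compound 4 (0.19 log units; within the scatter)). The earlier steps shown here only varied the group on a carbonyl carbon, whereas these replace the carbonyl itself and add a chlorine, and the four compounds still cannot be told apart. No measurement given here accounts for this result.

This step changes the linking group and the end group together, so a 4-chlorobenzoyl group on the same nitrogen would be needed to read each change alone. As far as these compounds go, whether an amine or a carboxylic acid on this nitrogen's substituent would give a step beyond the scatter also remains open.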